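Swapping a methoxy for a hydroxy in a cytotoxic series

The source may hold more compounds than are shown below. What is called first, only, known or untested is meant among the compounds shown, and "the series" means these compounds.

In a functional assay on A549 cells (Homo sapiens) for cytotoxicity (on this read-out higher numbers stand for weaker inhibition and lower numbers for stronger inhibition), compound 1 `COc1c(O)cc2c3c1C[C@@H](C)C[C@H](OC)[C@H](O3)[C@@H](C)/C=C(\C)[C@H](OC(N)=O)[C@@H](OC)C[C@@H](O)/C=C(\C)C(=O)N2` gives > 100000 nM, which is a limit of the assay and not a number. Compound 2 `COc1c(O)cc2c3c1C[C@@H](C)C[C@H](OC)[C@H](O3)[C@@H](C)/C=C(\C)[C@H](OC(N)=O)[C@@H](OC)/C=C/C=C(\C)C(=O)N2` gives 37000 nM. Compound 3 `COc1c(O)cc2cc1C[C@@H](C)C[C@H](OC)[C@H](O)[C@@H](C)/C=C(\C)[C@H](OC(N)=O)[C@@H](OC)CC/C=C(\C)C(=O)N2` gives 700 nM, the lower of the two actual numbers and beyond the scatter from its nearest neighbour, compound 2. Compound 4 `CO[C@H]1C[C@H](C)Cc2cc(cc(O)c2O)NC(=O)/C(C)=C/CC[C@H](OC)[C@@H](OC(N)=O)/C(C)=C/[C@H](C)[C@H]1O` differs from compound 3 by hydrogen in place of methyl on an oxygen on an aromatic ring, or methoxy to hydroxy. For the measured compounds named here, no measured pair isolates this change, so the expectation in this assay is loose: no step beyond the scatter, with either direction open. The estimated change is a 1.2-fold lower number from compound 3 to compound 4 (0.07 log units; within the scatter). For compound 4 the expected value is 600 nM, within an estimated range of 120 nM to 3000 nM.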

Compound 4, half-maximal inhibitory concentration: > 50000 nM
Compound 4 ended at the assay's limit; the forecaster's own chance of this, stated with the estimate: 3%; middle value at least 83-fold (1.92 log units) from the limit.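

For the compounds shown here, the only single-place step shows that the methoxy on the aromatic ring is not interchangeable with a hydroxy: hydrogen in place of methyl on that oxygen gives an at least 71-fold higher number from compound 3 to compound 4 (1.85 log units; beyond the scatter) in this assay. The earlier compounds shown here could not show this, as they differ from one another in more than one place. The result for compound 4 is a limit and not a number: the limit of > 50000 nM in this assay, at which 1 of the 4 values shown sits.

As far as these compounds go, it remains open whether the methyl itself is needed or whether any group on that oxygen would serve. An ethoxy or a longer alkoxy chain there could tell these apart.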